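The source may report more compounds than this note shows. Statements on the series, on what has been measured and on what is new or still open speak of the compounds shown alone.

Measured compounds:
compound 1 `O=C1COCCN1c1ccc(/N=C\c2cn(C(=O)c3ccccc3)c3ccccc23)cc1`, which gives 86.6%;
compound 2 `O=C1COCCN1c1ccc(/N=C\c2cn(Cc3ccccc3)c3ccccc23)cc1`, which gives 95.7%.

In an ADME assay on BV-2 cells (Mus musculus) for cytotoxicity, read by MTT assay, with a stated time of 48 h, tested at 15 uM (a lower number here means a stronger effect, a higher number a weaker effect of the compound at the concentration tested), compound 1 gives 86.6% and compound 2 gives 95.7%. For the measured compounds named here, the single step between them, a number 9.1 percentage points higher from compound 1 to compound 2 (within the scatter), lies within the scatter, so compound 2 and compound 1 are not separated by these numbers; compound 2 simply stands at one end of a pair that the assay does not tell apart.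

Compound 3 `O=C1COCCN1c1ccc(/N=C\c2cn(Cc3ccc(F)cc3)c3ccccc23)cc1` is the next compound. It differs from compound 2 in one place: fluoro in place of hydrogen on an aromatic carbon.

Going by the values given here, the only step measured so far touches the same region of the molecule, the group on the aromatic nitrogen, and a number 9.1 percentage points higher from compound 1 to compound 2 (within the scatter) stayed within the scatter even though it exchanged benzoyl for benzyl, a larger change than adding one fluorine. On that basis compound 3 is expected to show no step beyond the scatter, a number 2.7 percentage points lower from compound 2 to compound 3 (within the scatter). The estimate for compound 3 is therefore 93%, with a range from 80% to 102%.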

Compound 3, a percentage reported as activity, at one concentration (the size of the read-out at that concentration, not a potency): 86.1%
Compound 3: the middle estimate sits 6.9 percentage points above what was measured, within the range that was stated.
By their numbers in this assay, from the lowest: compounds 3, 1 and 2 (each within the scatter of the next).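

In this assay, for the compounds shown here, fluoro in place of hydrogen, para to a large group on the benzyl substituent, gives the first reading for a change on that six-membered aromatic ring of carbon only, and the step (a number 9.6 percentage points lower from compound 2 to compound 3 (within the scatter)) does not separate the two compounds. The comparison with the benzoyl compound (a number 0.5 percentage points lower from compound 1 to compound 3 (within the scatter)) does not separate those two either, so benzoyl, benzyl and 4-fluorobenzyl on the aromatic nitrogen remain a set that this assay does not tell apart. Nothing available here bears on why these readings fall as they do.

On these data alone, it remains open whether an amine or a carboxylic acid at this ring position, or a longer chain in place of benzyl on the aromatic nitrogen, would give a step beyond the scatter. These readings, each taken at one concentration, show only the size of the effect of all three compounds at that concentration, and they leave open whether any of the three would give a stronger or weaker effect at another concentration.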